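This account rests on a few compounds, and the source may have more. Where it says the series, first, only, none or still open, it means among the compounds named here.

Compound 1, `O=[N+]([O-])c1ccc(-c2noc(Cc3c[nH]c4ccccc34)n2)cc1`, in a functional assay on cells (Splenocyte, Mus musculus, strain BALB/c) for inhibition, read by scintillation counting and thymidine incorporation, with stated times of 48 h and 8 h (on this read-out lower numbers stand for stronger inhibition and higher numbers for weaker inhibition), gives only a limit, > 50000 nM.
Compound 2, `COc1cc(-c2noc(C34CCC(NC(=O)OC(C)(C)C)(CC3)CC4)n2)cc(OC)c1OC`, in this assay gives 2500 nM.

Compound 2 thus holds the only number shown; the other value is a limit, (the limit of > 50000 nM in this assay, at which 1 of the 2 values shown sits). Compound 3, `COc1cc(-c2noc(C34CCC(N)(CC3)CC4)n2)cc(OC)c1OC`, has not yet been measured. It differs from compound 2 by hydrogen in place of tert-butoxycarbonyl on an amine nitrogen. Among the compounds with values here, no measured pair shows a change of this kind, so its size is unknown here; the expectation is a modest weakening. In this assay compound 3 is estimated to give 6000 nM, with a range from 1500 nM to 30000 nM. The step of a 2.4-fold higher number from compound 2 to compound 3 (0.38 log units; beyond the scatter) is expected to lie a little beyond the scatter, toward weaker inhibition.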

Compound 3, half-maximal inhibitory concentration: 4800 nM
Beside the measured number, compound 3's estimate is 1.3-fold (0.10 log units) above it; low and high end bracket the measured number.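

In this assay, exchanging tert-butoxycarbonyl for hydrogen on this amine nitrogen gives a 1.9-fold higher number from compound 2 to compound 3 (0.28 log units; within the scatter) and so makes no clear difference. The bulky carbamate group is therefore not required for the inhibition seen here, and the free amine serves about equally well. Nothing measured here explains why this position accepts the exchange.

Still open, on these data alone, is whether a small group on this nitrogen, such as acetyl or methyl, would shift the inhibition. As far as these compounds go, it is also open whether a carboxylic acid in place of the amine would do so.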